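The source may report more compounds than this note shows. Statements on the series, on what has been measured and on what is new or still open speak of the compounds shown alone.

Measured compounds in a functional assay on MGC-803 cells (Homo sapiens) for inhibition, read by MTT assay, with a stated time of 72 h; a higher number here means a weaker inhibitor, a lower number a stronger inhibitor:
- compound 1 `Cc1cc(Nc2cc(-c3ccccc3)[nH]n2)n2ncnc2n1`: 21700 nM
- compound 2 `Cc1cc(Nc2ccn(Cc3nc(C)c4ccccc4n3)n2)n2nc(SCc3ccc(Br)cc3)nc2n1`: 960 nM
- compound 3 `Cc1cc(Nc2ccn(Cc3ccccc3)n2)n2nc(SCc3ccc(Br)cc3)nc2n1`: 4720 nM

Compound 1 gives the highest of the three numbers in this assay; compound 3 is the nearest, compound 2 the furthest. Among the measured compounds shown here, the only step measured in one place, a 4.9-fold higher number from compound 2 to compound 3 (0.69 log units; beyond the scatter), concerns a different part of the molecule and does not bear directly on the change at hand. Compound 4 `C#CCSc1nc2nc(C)cc(Nc3cc(-c4ccccc4)[nH]n3)n2n1` differs from compound 1 by propargylsulfanyl in place of hydrogen on an aromatic carbon. For the measured compounds named here, compounds 2 and 3 both carry a group attached through sulfur at that same aromatic carbon and both give lower numbers than compound 1, but each also differs from compound 1 elsewhere, so no clean measured step exists for this change. A modest drop is nonetheless expected, a 3.1-fold lower number from compound 1 to compound 4 (0.49 log units; beyond the scatter). Compound 4 is estimated at 7000 nM, range 2000 nM to 25000 nM.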

Compound 4, half-maximal inhibitory concentration: 13400 nM
Beside the measured number, compound 4's estimate is 1.9-fold (0.28 log units) below it, within the range that was stated.
By their numbers in this assay, from the lowest: compound 2; then compound 3; then compounds 4 and 1 (each within the scatter of the next).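

In this assay, among the compounds shown here, the first one-place reading at this position, on the aromatic carbon between two ring nitrogen atoms, is a 1.6-fold lower number from compound 1 to compound 4 (0.21 log units; within the scatter) and so shows no change beyond the scatter. On the core of compound 1, propargylsulfanyl is therefore tolerated in place of hydrogen, without a measurable gain. Nothing at hand explains this reading.

On these data alone, whether an amine or a longer alkylsulfanyl chain on this carbon would move the number beyond the scatter remains open. Also open, as far as these compounds go, is whether the flat result holds on the other cores.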